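Methoxycarbonyl to Dimethylcarbamoyl on the Chain

The source may report more compounds than this note shows. Statements on the series, on what has been measured and on what is new or still open speak of the compounds shown alone.

Compound 2 `C=CCc1cc(C(C)=O)c(O)cc1OCCCCCC(=O)OC` stands higher of the two compounds measured in an assay on isolated protein for inhibition of leukotriene B4 receptor 1 (Homo sapiens), tested at 10 uM; on this read-out higher numbers stand for more inhibition at the one concentration tested (going by the name of the read-out) and lower numbers for less inhibition: compound 2 gives 106%, whereas compound 1 `C=CCc1cc(C(C)=O)c(O)cc1OCCCCC#N` gives 92%. Within the data shown here, the only measured step, a number 14 percentage points higher from compound 1 to compound 2 (beyond the scatter), exchanged one group on this chain for another and lay beyond the scatter. Compound 3 `C=CCc1cc(C(C)=O)c(O)cc1OCCCCCC(=O)N(C)C` differs from compound 2 by dimethylamino in place of methoxy on a carbonyl carbon. The step from compound 1 to compound 2 bears on this only loosely, since it also alters the group carried on the same chain and shows that such alteration kept inhibition essentially complete. Among the measured compounds shown here, no measured pair probes the change from methoxycarbonyl to dimethylcarbamoyl itself. Compound 3 is therefore expected to stay close to compound 2, with a step of a number 6 percentage points lower from compound 2 to compound 3 (within the scatter) that lies within the scatter. Compound 3 is estimated at 100%, in a range from 80% to 115%.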

Compound 3, a percentage reported as inhibition, at one concentration (the size of the read-out at that concentration, not a potency): 92%
For compound 3 the middle estimate is 8 percentage points above the measured one, within the range that was stated.
By their numbers in this assay, from the lowest: compounds 1 and 3 (each within the scatter of the next); then compound 2.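

Here the change from methoxycarbonyl to dimethylcarbamoyl on the chain can be read directly: in this assay, dimethylamino in place of methoxy on the carbonyl carbon gives a number 14 percentage points lower from compound 2 to compound 3 (beyond the scatter), so the two carbonyl groups are not interchangeable at this position. The comparison with the nitrile gives no change at the digits printed from compound 1 to compound 3 (within the scatter), which leaves compound 2 as the only one of the three that stands apart, with its steps to both others beyond the scatter. Nothing available accounts for why the methoxycarbonyl chain reads higher than the other two.

The compounds shown leave open how a carboxylic acid or a primary amide at the end of this chain would read in this assay. They also leave open whether a shorter or longer chain carrying methoxycarbonyl would keep the number seen for compound 2.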